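Trimming the Side Chain from Compound 1 to Compound 4

This account rests on a few compounds, and the source may have more. Where it says the series, first, only, none or still open, it means among the compounds named here.

Compound 1 `CCOC(=O)c1ccc(-c2nn(Cc3cccc(F)c3)c3ccccc23)cc1` is one of three compounds tested in a functional assay on cells (Platelet, Homo sapiens) for inhibition (on this read-out higher numbers stand for weaker inhibition and lower numbers for stronger inhibition), and for compound 1 the result is only a limit, > 10000 nM. Compound 2 `CCOC(=O)c1ccc(-c2nn(Cc3ccccn3)c3ccccc23)cc1` likewise reaches only the limit > 10000 nM. Compound 3 `CCOC(=O)c1ccc(-c2nn(-c3ccco3)c3ccccc23)cc1` also stops at the limit > 10000 nM. The steps a step that the two limits leave unreadable from compound 1 to compound 2 and a step that the two limits leave unreadable from compound 1 to compound 3 therefore cannot be read, and the limit of > 10000 nM in this assay, at which 3 of the 3 values shown sit, is all the evidence there is. Compound 4 `CCCn1nc(-c2ccc(C(=O)OCC)cc2)c2ccccc21` differs from compound 1 by ethyl in place of 3-fluorophenyl on a saturated chain carbon bound to an aromatic nitrogen. Going by the values given here, no measured step shows what such a change does, and because the limit of > 10000 nM in this assay, at which 3 of the 3 values shown sit, places every value at the limit, compound 4 is expected to stay there too. The step expected here is a step that the limit leaves unreadable from compound 1 to compound 4. Compound 4 is estimated at 20000 nM, within 5000 nM to 80000 nM.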

Compound 4, half-maximal inhibitory concentration: > 10000 nM
Compound 4 was reported as a limit; the forecaster's own chance of this, stated with the estimate: 85%; the middle value does not contradict the limit.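

Compound 4 ends at a limit, as do compound 1, compound 2 and compound 3, so no step to compound 4 can be read: the limit of > 10000 nM in this assay, at which 4 of the 4 values shown sit.

The compounds shown leave open which group on the aromatic nitrogen, if any, would give a measurable value in this assay.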